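A few compounds are considered here, and "the series" means these few. Any claim that something is new, unique, unknown or untested is made for them only; others in the source may bear on it.

In a functional assay on CHO cells for antagonist activity at transient receptor potential cation channel subfamily V member 1 (Rattus norvegicus) (on this read-out higher numbers stand for weaker inhibition and lower numbers for stronger inhibition), compound 1 `Cc1ccc(CNC(=O)C(C)c2ccc(NS(C)(=O)=O)c(F)c2)cc1` gives 930 nM, while compound 2 `CC(C(=O)NCc1ccc(C2C=CCC2)cc1)c1ccc(NS(C)(=O)=O)c(F)c1` gives 15 nM; the step of a 62-fold lower number from compound 1 to compound 2 (1.79 log units; beyond the scatter) is the only measured one, and compound 2 therefore holds the lowest number of the two. Compound 3 `CC(C(=O)NCc1ccc(C2CCCC2)cc1)c1ccc(NS(C)(=O)=O)c(F)c1` differs from compound 2 by cyclopentyl in place of cyclopent-2-en-1-yl on an aromatic carbon. Within the data shown here, no measured step bears directly on this change, and the saturation of one five-membered carbon ring is expected to leave the number close to that of compound 2, with a 1.3-fold higher number from compound 2 to compound 3 (0.12 log units; within the scatter) as the expected step. Compound 3 is therefore estimated at 20 nM, within 7 nM to 60 nM.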

Compound 3, inhibition constant: 20.8 nM
Beside the measured number, compound 3's estimate is 1.0-fold (0.02 log units) below it; measured number inside the range.
By their numbers in this assay, from the lowest: compounds 2 and 3 (each within the scatter of the next); then compound 1.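

In this assay, the double bond of cyclopent-2-en-1-yl proves dispensable on this aromatic carbon, para to a large group: the change to cyclopentyl gives a 1.4-fold higher number from compound 2 to compound 3 (0.14 log units; within the scatter) and stays within the scatter. The saturated ring also keeps a large margin over methyl, with a 45-fold lower number from compound 1 to compound 3 (1.65 log units; beyond the scatter) on the same position. No evidence is available to explain why either five-membered ring differs so much from methyl. The compounds shown leave open whether cyclobutyl, cyclohexyl or phenyl would serve here, and whether a ring holding an oxygen atom, such as tetrahydrofuranyl, or an open butyl chain would do the same.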